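A few compounds are considered here, and "the series" means these few. Any claim that something is new, unique, unknown or untested is made for them only; others in the source may bear on it.

Compound 1 `COc1ccc(C(=O)C2Sc3nnc(-c4cc(OC)c(OC)c(OC)c4)n3NC2c2ccco2)cc1`: in a functional assay on PC-3 cells (Homo sapiens) for cytotoxicity, read by MTT assay, with a stated time of 48 h (on this read-out higher numbers stand for weaker inhibition and lower numbers for stronger inhibition), compound 1 gives > 100000 nM, which is a limit of the assay and not a number.
Compound 2 `COc1cc(-c2nnc3n2NC(c2ccco2)C(C(=O)c2ccc(Cl)cc2)S3)cc(OC)c1OC`: in this assay compound 2 gives 67800 nM.

Compound 1 stands at the limit of > 100000 nM in this assay, at which 1 of the 2 values shown sits, so only a limit is known for it. Compound 3 `COc1cc(-c2nnc3n2NC(c2ccco2)C(C(=O)c2ccc(F)cc2)S3)cc(OC)c1OC` differs from compound 1 by fluoro in place of methoxy on an aromatic carbon. Going by the values given here, the one measured step that bears on this change is an at least 1.4-fold lower number from compound 1 to compound 2 (0.16 log units; that floor lies within the scatter), and it lies within the scatter. A change of similar kind is therefore expected to move this assay little, if at all. The expected step is an at least 1.0-fold lower number from compound 1 to compound 3 (0.02 log units; that floor lies within the scatter). Compound 3 is estimated at 95000 nM, with a range from 50000 nM to 200000 nM.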

Compound 3, half-maximal inhibitory concentration: 27700 nM
Estimate against measurement, compound 3: 3.4-fold (0.54 log units) above; measured number outside the range, below it.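

In this assay, going by these compounds alone, fluoro gives the first step at this position that clearly exceeds the scatter: an at least 3.6-fold lower number from compound 1 to compound 3 (0.55 log units; beyond the scatter). The two halogens also differ here, with a 2.4-fold lower number from compound 2 to compound 3 (0.39 log units; beyond the scatter), so the choice of halogen matters and not only the loss of methoxy. Compound 1 stands at a limit of the assay, so the first step is only a floor: the limit of > 100000 nM in this assay, at which 1 of the 3 values shown sits.

On these data alone, what a plain hydrogen, an amine or a nitrile would give at this place stays open. So does whether fluoro would give a similar step on a different core.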